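Chloro on the furan-2-yl group of compound 2

The compounds below may be only part of what the source reports. "The series", "measured", "known", "first", "only" and "open" are said of these compounds alone.

compound 1 `Cc1ccsc1-c1cc(-c2ccco2)cc(-c2ccc(Cl)cc2)n1`: 20700 nM
compound 2 `Clc1ccc(-c2cc(-c3ccco3)cc(-c3ccc(Cl)s3)n2)cc1`: 10500 nM
compound 3 `Cc1ccc(-c2cc(-c3ccoc3)cc(-c3ccc(Cl)s3)n2)cc1`: 17900 nM

These three compounds were tested in a functional assay on K562 cells (Homo sapiens) for cytotoxicity, read by ELISA, with a stated time of 4 days; a higher number here means a weaker inhibitor, a lower number a stronger inhibitor. There, compound 2 gives 10500 nM, a value within the usual scatter of both compound 1 and compound 3, so the three cannot be ranked.

The untested compound 4 `Clc1ccc(-c2cc(-c3ccc(Cl)o3)cc(-c3ccc(Cl)s3)n2)cc1` differs from compound 2 in one place chloro in place of hydrogen on an aromatic carbon: furan-2-yl becomes 5-chlorofuran-2-yl. For the measured compounds named here, only one measured step compares two compounds that differ in one place, a 2.0-fold lower number from compound 1 to compound 2 (0.29 log units; within the scatter). That step swaps 3-methylthiophen-2-yl for 5-chlorothiophen-2-yl and leaves the furan-2-yl group untouched, so it bears on the new change only indirectly. Going by the values given here, no measured pair shows what chloro does on the furan-2-yl group itself. It does suggest that a single swap in this small set need not move the number much, so no step beyond the scatter is expected in this assay, in either direction.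

For compound 4 the estimated value is 9000 nM, with an expected range of 4000 nM to 20000 nM. This estimate means a 1.2-fold lower number from compound 2 to compound 4 (0.07 log units; within the scatter).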

Compound 4, half-maximal inhibitory concentration: 19300 nM
Estimate against measurement, compound 4: 2.1-fold (0.33 log units) below; the measured number falls inside the stated range.
By their numbers in this assay, from the lowest: compounds 2, 3, 4 and 1 (each within the scatter of the next).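

In this assay, chloro in place of hydrogen on an aromatic carbon gives a 1.8-fold higher number from compound 2 to compound 4 (0.26 log units; within the scatter). For the compounds shown here, this is the first direct reading at this position, next to the ring oxygen, and it shows that turning furan-2-yl into 5-chlorofuran-2-yl does not move the number beyond the scatter, so the added chloro can be called neither a gain nor a loss here. No measurement is available that would explain this result.

The compounds shown leave open whether a different group on this same carbon, such as an amine, a carboxylic acid or a longer alkyl chain, would shift the number beyond the scatter. They also leave open whether chloro at this position would give a similar reading on the core of compound 1, which carries 3-methylthiophen-2-yl.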